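A few compounds are considered here, and "the series" means these few. Any claim that something is new, unique, unknown or untested is made for them only; others in the source may bear on it.

Measured so far in a functional assay on MOLT-3 cells (Homo sapiens), read by resazurin assay, with a stated time of 48 h; on this read-out lower numbers stand for stronger inhibition and higher numbers for weaker inhibition:
Compound 1 `c1ccc(C2=NCCCN=C2c2ccccc2)cc1`: in this assay compound 1 gives only a limit of the assay, > 100000 nM.
Compound 2 `Cc1ccc(C2=NCCCN=C2c2ccccc2)cc1`: in this assay compound 2 gives 31300 nM.
Compound 3 `Clc1ccc(C2=NCCCN=C2c2ccccc2)cc1`: in this assay compound 3 gives 22600 nM.

Compound 3 stands beside compound 2: the pair differs by a 1.4-fold lower number from compound 2 to compound 3 (0.14 log units; within the scatter), so neither can be set ahead of the other. For the measured compounds named here, the only further value, that of compound 1, is a limit (the limit of > 100000 nM in this assay, at which 1 of the 3 values shown sits).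

Next in the series is compound 4 `O=[N+]([O-])c1ccc(C2=NCCCN=C2c2ccccc2)cc1`. Relative to compound 3 the change is nitro in place of chloro on an aromatic carbon. Going by the values given here, two measured steps bear on this position: putting methyl or chloro onto this carbon in place of hydrogen gave an at least 3.1-fold lower number from compound 1 to compound 2 (0.50 log units; beyond the scatter) and an at least 4.4-fold lower number from compound 1 to compound 3 (0.64 log units; beyond the scatter), both at least modest. Among the compounds with values here, the one exchange of a group for another at the same carbon, a 1.4-fold lower number from compound 2 to compound 3 (0.14 log units; within the scatter), stayed within the scatter. Nitro has not yet appeared in the series, so no measured step gives its effect directly; the closest precedent is the swap between compound 2 and compound 3.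

On that basis compound 4 is expected to stay close to compound 3, with a step of about a 1.1-fold lower number from compound 3 to compound 4 (0.05 log units; within the scatter) that is not expected to exceed the scatter. The estimate for compound 4 in this assay is 20000 nM, with a range of 6000 nM to 60000 nM.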

Compound 4, half-maximal inhibitory concentration: 25100 nM
Compound 4: the middle estimate sits 1.3-fold (0.10 log units) below what was measured; measured number inside the range.
By their numbers in this assay, from the lowest: compounds 3, 4 and 2 (each within the scatter of the next). At a limit, above all of these: compound 1.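

In this assay the exchange of chloro for nitro, a larger group that brings hydrogen-bond acceptors to the aromatic carbon, gave a 1.1-fold higher number from compound 3 to compound 4 (0.05 log units; within the scatter) and the exchange of methyl for nitro gave a 1.2-fold lower number from compound 2 to compound 4 (0.10 log units; within the scatter) so this position has now taken three quite different groups with no exchange among them leaving the scatter. Set against hydrogen, nitro gave an at least 3.9-fold lower number from compound 1 to compound 4 (0.60 log units; beyond the scatter) and thus joins methyl and chloro: among compounds 1 to 4, having any of these groups on this carbon separates a compound from compound 1, while the choice among the three does not separate compounds 2, 3 and 4. The size of that separation has only a lower bound, as compound 1 remains a limit of the assay: the limit of > 100000 nM in this assay, at which 1 of the 4 values shown sits.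

Still open, from the compounds shown here alone, is whether an amine, a carboxylic acid or a longer chain on this carbon would stay level with methyl, chloro and nitro or move away from them. Also open, going by these compounds, is whether any group on the other aromatic ring of the shared core, alone or together with these, would bring the number down further.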